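Bringing back the urea-type group on the carbonyl carbon

This account rests on a few compounds, and the source may have more. Where it says the series, first, only, none or still open, it means among the compounds named here.

Compound 1 `COc1cc(-c2nn(-c3cccc(NC(=O)Nc4ccc(Cl)c(C(F)(F)F)c4)c3)cc2-c2ccncc2)ccc1Cl` gives 29200 nM in a functional assay on UACC-257 cells (Homo sapiens) for inhibition, read by sulforhodamine B assay, with a stated time of 48 h; a higher number here means that more compound is tolerated, a lower number that less compound is tolerated.
Compound 2 `COc1cc(-c2nn(-c3cccc(NC(=O)c4ccccc4)c3)cc2-c2ccncc2)ccc1Cl` gives > 100000 nM in this assay, which is a limit of the assay and not a number.

Compound 2 therefore sits at the limit (the limit of > 100000 nM in this assay, at which 1 of the 2 values shown sits), so its true value is known only as lying past that point. Among the measured compounds shown here, the single measured step, an at least 3.4-fold higher number from compound 1 to compound 2 (0.53 log units; beyond the scatter), shows that swapping the substituted amino group for a plain phenyl on the carbonyl carbon pushes the value out of the measurable range. Compound 3 `COc1cc(-c2nn(-c3cccc(NC(=O)Nc4ccc(Cl)c(Cl)c4)c3)cc2-c2ccncc2)ccc1Cl` reverses that move with a different ring: (3,4-dichlorophenyl)amino in place of phenyl on a carbonyl carbon. Since this change brings back a group of the same kind as the one whose loss was seen in an at least 3.4-fold higher number from compound 1 to compound 2 (0.53 log units; beyond the scatter), the step of an at least 3.3-fold lower number from compound 2 to compound 3 (0.52 log units; beyond the scatter) is expected to be a fall from the limit back towards the value of compound 1, rather than no change. Compound 3 is thus estimated at 30000 nM, within a range of 10000 nM to 90000 nM.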

Compound 3, concentration lethal to 50% of the cells: > 50000 nM
Compound 3: only a limit was reported; the forecaster's own chance of this, stated with the estimate: 20%; at least 1.6-fold (0.22 log units) between middle value and limit.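

Compound 3 also ends at a limit of the assay and not at a number: the limit of > 50000 nM in this assay, at which 1 of the 3 values shown sits. The step between compound 2 and compound 3 cannot be read, as both are limits, so restoring an amino-linked ring on the carbonyl carbon, here (3,4-dichlorophenyl)amino, is not enough on its own to give a measured value, and compound 1 remains the only one of the three with a number in this assay. Among the compounds shown here, the single readable comparison, chloro in place of trifluoromethyl on an aromatic carbon, gives an at least 1.7-fold higher number from compound 1 to compound 3 (0.23 log units; that floor lies within the scatter), so this floor alone does not establish a real difference between the two groups at this position, although the true gap could be larger.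

From the compounds shown here alone, how far the true value of compound 3 lies past its limit stays open, and with it whether trifluoromethyl matters at this position at all. The compounds shown also leave open what a bromo or a methyl group on that same aromatic carbon would do in this assay.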